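The source may report more compounds than this note shows. Statements on the series, on what has been measured and on what is new or still open speak of the compounds shown alone.

Compound 1 `CN1CCC[C@H]1COc1cncc(-c2ccc(F)cc2)c1`: 0.11 nM
Compound 2 `Cc1ccc(-c2cncc(OC[C@@H]3CCCN3C)c2)cc1`: 0.13 nM

Of the compounds shown here, two that share a core have been measured in an assay on membranes from brain for binding affinity to Neuronal acetylcholine receptor; alpha4/beta2 (Rattus norvegicus); a lower number here means a stronger inhibitor, a higher number a weaker inhibitor. Compound 1 `CN1CCC[C@H]1COc1cncc(-c2ccc(F)cc2)c1` gives 0.11 nM, the lowest of the two numbers, and compound 2 `Cc1ccc(-c2cncc(OC[C@@H]3CCCN3C)c2)cc1` gives 0.13 nM; the two stand within the scatter of each other. Going by the values given here, the single measured step, a 1.2-fold higher number from compound 1 to compound 2 (0.07 log units; within the scatter), a methyl in place of fluoro on an aromatic carbon, stays within the scatter, so neither compound can be called the stronger.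

Compound 3 `CN1CCC[C@H]1COc1cncc(-c2ccc(F)c(Cl)c2)c1` has not yet been measured in this assay. It differs from compound 1 by chloro in place of hydrogen on an aromatic carbon. Among the compounds with values here, no measured step describes an added chloro on this ring; the only step at hand concerns a swap of the fluoro itself, and it was within the scatter. On that thin evidence, a small step in either direction, or none beyond the scatter, is expected. Compound 3 is therefore estimated to give about 0.15 nM in this assay, with a range from 0.04 nM to 0.6 nM. The step this estimate implies, a 1.4-fold higher number from compound 1 to compound 3 (0.13 log units; within the scatter), is expected to lie close to the scatter.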

Compound 3, inhibition constant: 0.055 nM
The estimate for compound 3 lay 2.7-fold (0.44 log units) above the measured number, and the stated range covers the measured number.
By their numbers in this assay, from the lowest: compounds 3, 1 and 2 (each within the scatter of the next, the first and the last beyond it).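

In this assay, the earlier pair spoke only to a swap of the group para... 

Correction, in the permitted wording: in this assay, the earlier pair spoke only to replacing the fluoro group itself, whereas compound 3 is the first to probe a different place, an aromatic carbon ortho to a fluoro group and meta to a large group, where chloro enters in place of hydrogen. The step, a 2.0-fold lower number from compound 1 to compound 3 (0.30 log units; within the scatter), stays within the scatter, so this added chlorine atom cannot be said to change the number, and this position accepts a chloro group with no loss that can be read. Nothing at hand offers any explanation of this result.

The compounds shown leave open whether this position would accept anything other than a single chlorine atom, such as a methoxy group, an amine or a carboxylic acid, since one substituent cannot define what the position allows. They also leave open whether the chloro group would give the same result alongside the methyl group of compound 2, or with hydrogen in place of the fluoro group of compound 3.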